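Aryl Amine to Benzyl Amine: Expecting Compound 4

A few compounds are considered here, and "the series" means these few. Any claim that something is new, unique, unknown or untested is made for them only; others in the source may bear on it.

compound 1, `CCOC(=O)CNc1nc(Nc2cccc(OC)c2)ncc1[N+](=O)[O-]`: > 100000 nM
compound 2, `COC(=O)CN(C)c1nc(Nc2ccccc2)ncc1[N+](=O)[O-]`: > 100000 nM
compound 3, `CCOC(=O)CN(Cc1ccccc1)c1nc(NCc2cccc(OC)c2)ncc1[N+](=O)[O-]`: 33600 nM

All three measured compounds were tested in a functional assay on HepG2 cells (Homo sapiens) for antiproliferative activity, read by MTT assay, with a stated time of 48 h; on this read-out higher numbers stand for weaker inhibition and lower numbers for stronger inhibition. For compound 1 the result is only a limit of the assay, > 100000 nM. For compound 2 the result is likewise a limit, > 100000 nM. Within the data shown here, compound 3 is the one compound that gives a number, 33600 nM. Among the measured compounds shown here, compound 1 therefore stands at the limit of > 100000 nM in this assay, at which 2 of the 3 values shown sit, and no step with a measured size connects it to any other compound in this set.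

The unmeasured compound 4, `CCOC(=O)CNc1nc(NCc2ccccc2)ncc1[N+](=O)[O-]`, differs from compound 1 in one place: benzyl in place of 3-methoxyphenyl on a nitrogen on an aromatic ring. For the measured compounds named here, no measured pair isolates this change. Going by the values given here, the value of compound 3 shows only that a number inside the measurable range of this assay is attainable for a related structure; it does not describe the step from compound 1.

With compound 1 at a limit, the expected step in this assay has no numbered anchor; the expectation is for no change beyond the scatter, with a value that may still sit at the limit. Compound 4 is estimated at 90000 nM, between 30000 nM and 300000 nM. The implied an at least 1.1-fold lower number from compound 1 to compound 4 (0.04 log units; that floor lies within the scatter) is expected to be small.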

Compound 4, half-maximal inhibitory concentration: > 100000 nM
Compound 4 gave a limit, no number; the forecaster's own chance of this, stated with the estimate: 55%; middle value at least 1.1-fold (0.04 log units) from the limit.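

In this assay compound 4 gives > 100000 nM as a limit of the assay, not a number. Among these compounds, compound 1 is also a limit, so no step from compound 1 to compound 4 can be read: the limit of > 100000 nM in this assay, at which 3 of the 4 values shown sit. The compounds shown leave open whether benzyl in place of 3-methoxyphenyl changes the result in this assay at all.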